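The compounds below may be only part of what the source reports. "The series", "measured", "known", "first", "only" and "open" are said of these compounds alone.

In a physicochemical assay, with a stated time of 30 min (a lower number here means that less compound is needed, a higher number that more compound is needed for the effect), compound 1 `C/C(=N\N=C1/SCC(=O)N1Cc1cccc(F)c1)c1cccs1` gives 2550000 nM, and compound 2 `CC(C)=N/N=C1\SCC(=O)N1Cc1ccc(N)cc1` gives 1770000 nM. These two values lie within the usual scatter of each other, so the numbers do not separate compound 1 from compound 2. Compound 3 `C/C(=N\N=C1/SCC(=O)N1Cc1ccccc1F)c1cccs1` has the same atoms as compound 1, joined differently: 2-fluorophenyl in place of 3-fluorophenyl on a saturated chain carbon bound to an amide-type nitrogen in a ring. Within the data shown here, no measured pair shows a comparable change, so no step beyond the scatter is expected in this assay, in either direction. The estimated value for compound 3 is 2300000 nM, within an expected range of 1100000 nM to 4800000 nM. The expected change is a 1.1-fold lower number from compound 1 to compound 3 (0.04 log units; within the scatter).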

Compound 3, half-maximal effective concentration: 2400000 nM
Beside the measured number, compound 3's estimate is 1.0-fold (0.02 log units) below it, within the range that was stated.
By their numbers in this assay, from the lowest: compounds 2, 3 and 1 (each within the scatter of the next).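

With 2-fluorophenyl in place of 3-fluorophenyl on a saturated chain carbon bound to an amide-type nitrogen in a ring, this assay gives (a 1.1-fold lower number from compound 1 to compound 3 (0.03 log units; within the scatter)). Among these compounds, this is the first comparison in which only one place differs, and it shows that this read-out does not separate the two fluorophenyl groups at this position. No evidence offers an explanation for this result. The compounds shown leave open whether a carboxylic acid on the phenyl ring, or a longer chain at this position, would give a step beyond the scatter.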